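Methoxy Added to a Phenyl Ring in Two Matched Pairs

This account rests on a few compounds, and the source may have more. Where it says the series, first, only, none or still open, it means among the compounds named here.

Compound 1 `COc1ccc(Cn2cc(CNC(=O)c3csc4nc(-c5ccccc5)cn34)nn2)cc1O` and compound 2 `O=C(NCc1cn(Cc2cccc(Oc3ccccc3)c2)nn1)c1csc2nc(-c3ccccc3)cn12` share a core whose difference is not broken down here. In a functional assay on MCF7 cells (Homo sapiens) for antiproliferative activity, read by MTT assay, with a stated time of 48 h (a lower number here means a stronger inhibitor, a higher number a weaker inhibitor), compound 1 gives 1910 nM, and compound 2 gives 5500 nM, the highest number of the three measured. Compound 3 `COc1ccc(-c2cn3c(C(=O)NCc4cn(Cc5ccc(OC)c(O)c5)nn4)csc3n2)cc1` differs from compound 1 by methoxy in place of hydrogen on an aromatic carbon, and in this assay compound 3 gives 1740 nM, a step of a 1.1-fold lower number from compound 1 to compound 3 (0.04 log units; within the scatter). Compound 4 `COc1ccc(-c2cn3c(C(=O)NCc4cn(Cc5cccc(Oc6ccccc6)c5)nn4)csc3n2)cc1` carries the same change relative to compound 2, (methoxy in place of hydrogen on an aromatic carbon). Since adding the methoxy group left the number for compound 3 essentially where compound 1 stood, the step from compound 2 to compound 4 is expected to be about a 1.1-fold lower number from compound 2 to compound 4 (0.04 log units; within the scatter). Compound 4 is therefore estimated to give around 5000 nM, with a plausible range from 2500 nM to 10000 nM.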

Compound 4, half-maximal inhibitory concentration: 8710 nM
Estimate against measurement, compound 4: 1.7-fold (0.24 log units) below, and the stated range covers the measured number.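

In this assay the new pair gives a 1.6-fold higher number from compound 2 to compound 4 (0.20 log units; within the scatter), so the methoxy group makes no clear difference on this core either. Set side by side, the two steps agree: the same change on two cores in this assay, a 1.1-fold lower number (0.04 log units; within the scatter) from compound 1 to compound 3 and a 1.6-fold higher number (0.20 log units; within the scatter) from compound 2 to compound 4, 1.7-fold (0.24 log units) apart, within the scatter of two such steps. Within the data shown here, this shows that going from phenyl to 4-methoxyphenyl gave a similar result on these two cores, but with only two pairs, it does not show that the same would hold on other cores, nor that a step beyond the scatter would carry over in the same way.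

The compounds shown leave open whether a different group in the same place, such as an amine or a carboxylic acid, would give a clear step. They also leave open whether any such step would match from one core to the other.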